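The source may hold more compounds than are shown below. What is called first, only, known or untested is meant among the compounds shown, and "the series" means these compounds.

Compounds measured in an assay on L1.2 cells for binding affinity to C-C chemokine receptor type 8 (Homo sapiens); on this read-out higher numbers stand for weaker inhibition and lower numbers for stronger inhibition:
compound 1, `Cc1ccccc1C(=O)Nc1ccc(S(=O)(=O)NC2CCN(C(=O)C3CCCC3)CC2)c2ccccc12`, 9.1 nM;
compound 2, `Cc1ccccc1C(=O)Nc1ccc(S(=O)(=O)NC2CCN(C(=O)CN)CC2)c2ccccc12`, 4.1 nM;
compound 3, `Cc1ccccc1C(=O)Nc1ccc(S(=O)(=O)NC2CCN(C(=O)CCN)CC2)c2ccccc12`, 11.3 nM.

Compound 3 has the highest of the three numbers. Its gap to compound 1 is small, a 1.2-fold higher number from compound 1 to compound 3 (0.09 log units; within the scatter), and stays within the scatter, so the two cannot be ordered. Its gap to compound 2 is larger, a 2.8-fold higher number from compound 2 to compound 3 (0.44 log units; beyond the scatter), and lies beyond the scatter. The third step, a 2.2-fold lower number from compound 1 to compound 2 (0.35 log units; beyond the scatter), is of the same modest size.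

Compound 4, `Cc1ccccc1C(=O)Nc1ccc(S(=O)(=O)NC2CCN(C(N)=O)CC2)c2ccccc12`, differs from compound 3 in one place: amino in place of 2-aminoethyl on a carbonyl carbon. The measured steps bear on this only at a distance. Both steps to compound 2 show that a shorter substituent on that carbonyl carbon went with a lower number, so a further shortening in compound 4 may be expected to move in the same direction, by a modest step at most, a 1.6-fold lower number from compound 3 to compound 4 (0.21 log units; within the scatter). Among the compounds with values here, no step in this set removes the chain entirely, so the range is kept wide. For compound 4 the estimate in this assay is 7 nM, between 2.5 nM and 25 nM.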

Compound 4, inhibition constant: 243 nM
Compound 4: the middle estimate sits 35-fold (1.54 log units) below what was measured; measured number above the stated range.
By their numbers in this assay, from the lowest: compound 2; then compounds 1 and 3 (each within the scatter of the next); then compound 4.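

In this assay, within the data shown here, the carbonyl carbon on the amide-type nitrogen in a ring had so far carried cyclopentyl, aminomethyl and 2-aminoethyl with only modest steps among them, but amino on that carbon gives large steps against all three (a 22-fold higher number from compound 3 to compound 4 (1.33 log units; beyond the scatter); a 59-fold higher number from compound 2 to compound 4 (1.77 log units; beyond the scatter); a 27-fold higher number from compound 1 to compound 4 (1.43 log units; beyond the scatter)). An amino group as such does not set the level: compound 2 and compound 3 carry one at the end of a chain and compound 1 has none, whereas compound 4 alone has it directly on the carbonyl carbon. No measurement shown here gives a reason for this large step.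

From the compounds shown here alone, it remains open whether the step follows from the amino group on that carbon or from the missing carbon chain. A methyl group or a methylamino group on the carbonyl carbon would tell these apart.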